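The source may hold more compounds than are shown below. What is called first, only, known or untested is meant among the compounds shown, and "the series" means these compounds.

Compound 1 `Clc1ccc(-c2nc(NCCNc3ccccn3)ncc2-c2ncc[nH]2)c(Cl)c1`: > 0.5 h
Compound 2 `Nc1nc(NCCNc2ncc(-c3ncc[nH]3)c(-c3ccccc3Br)n2)ccc1[N+](=O)[O-]`: > 0.5 h

In an ADME assay on microsomes from liver (Canis lupus familiaris) for metabolic stability (a lower number here means that the compound disappears faster, a higher number that the compound lasts longer), compound 1 gives a limit rather than a number, > 0.5 h. Compound 2 likewise reaches a limit, > 0.5 h. Both values sit at the limit of > 0.5 h in this assay, at which 2 of the 2 values shown sit, so compound 2 stands at the edge of what this assay reports, alongside compound 1. Compound 3 `Nc1nc(NCCNc2ncc(-c3ncc[nH]3)c(-c3ccc(F)cc3Br)n2)ccc1[N+](=O)[O-]` has not yet been measured. It differs from compound 2 as follows: fluoro in place of hydrogen on an aromatic carbon. For the measured compounds named here, no step between measured compounds is known, and no shift beyond the usual scatter is expected in this assay. Compound 3 is expected to give about 0.8 h, between 0.4 h and 2 h. The expected step is a step that the limit leaves unreadable from compound 2 to compound 3.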

Compound 3, half-life: > 0.5 h
Compound 3: no number, only a limit; the forecaster's own chance of this, stated with the estimate: 70%; the middle value lies beyond the limit too.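

For the compounds shown here, no step from compound 2 to compound 3 can be read in this assay, as both give only a limit: the limit of > 0.5 h in this assay, at which 3 of the 3 values shown sit. The compounds shown leave open how long any of the three actually lasts, and whether fluoro in place of hydrogen matters.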